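The compounds below may be only part of what the source reports. "The series", "measured", "known", "first", "only" and "open" are said of these compounds alone.

Of the compounds shown here, three on a shared core have been tested in a functional assay on DU-145 cells (Homo sapiens) for cytotoxicity, read by sulforhodamine B assay, with a stated time of 48 h (on this read-out lower numbers stand for stronger inhibition and higher numbers for weaker inhibition), and they differ in the aromatic group on a carbon with a double bond to nitrogen. Compound 1 (`C[C@H]1CC[C@@H]2[C@@H](OC(=O)[C@]23CC(c2ccccc2[N+](=O)[O-])=NO3)[C@]2(C)C(=O)C=C[C@@]12O`), with 2-nitrophenyl, gives 34000 nM there. Compound 2 (`COc1ccc(C2=NO[C@]3(C2)C(=O)O[C@@H]2[C@H]3CC[C@H](C)[C@]3(O)C=CC(=O)[C@@]23C)cc1OC`), with 3,4-dimethoxyphenyl, gives 84000 nM there, and compound 3 (`COc1cc(C2=NO[C@]3(C2)C(=O)O[C@@H]2[C@H]3CC[C@H](C)[C@]3(O)C=CC(=O)[C@@]23C)ccc1O`), with 4-hydroxy-3-methoxyphenyl, gives 71000 nM on the same read-out. Compound 3 therefore sits at the weak end of this small set, level with compound 2, while compound 1 has the lower number.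

Compound 4 (`Cc1ccc(C2=NO[C@]3(C2)C(=O)O[C@@H]2[C@H]3CC[C@H](C)[C@]3(O)C=CC(=O)[C@@]23C)cc1`), not yet measured, carries 4-methylphenyl in place of 4-hydroxy-3-methoxyphenyl (4-methylphenyl in place of 4-hydroxy-3-methoxyphenyl on a carbon with a double bond to nitrogen) on that same carbon. Going by the values given here, no tested compound carries this group, so the guide is only indirect. Replacing 2-nitrophenyl gave modest steps, a 2.5-fold higher number from compound 1 to compound 2 (0.39 log units; beyond the scatter) and a 2.1-fold higher number from compound 1 to compound 3 (0.32 log units; beyond the scatter) in turn. Hydrogen in place of methyl on an oxygen on an aromatic ring gave a 1.2-fold lower number from compound 2 to compound 3 (0.07 log units; within the scatter) and so separates nothing. Across these compounds the aromatic group has never moved the number far, so the expected move in this assay is small, an estimated 1.2-fold lower number from compound 3 to compound 4 (0.07 log units; within the scatter) with no clear direction. For compound 4 the estimate is 60000 nM as the expected value, with 28000 nM to 120000 nM as its range.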

Compound 4, half-maximal inhibitory concentration: 14000 nM
Compound 4: the middle estimate sits 4.3-fold (0.63 log units) above what was measured; measured number outside the range, below it.
By their numbers in this assay, from the lowest: compound 4; then compound 1; then compounds 3 and 2 (each within the scatter of the next).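

Swapping the aromatic group on the carbon with a double bond to nitrogen can matter more than the earlier compounds suggested: in this assay, 4-methylphenyl in place of 4-hydroxy-3-methoxyphenyl gives a 5.1-fold lower number from compound 3 to compound 4 (0.71 log units; beyond the scatter), and 4-methylphenyl in place of 3,4-dimethoxyphenyl gives a 6.0-fold lower number from compound 2 to compound 4 (0.78 log units; beyond the scatter), both larger than any earlier step at this position. The new group also outdoes the 2-nitrophenyl group, with a 2.4-fold lower number from compound 1 to compound 4 (0.39 log units; beyond the scatter), so the position still responds to the group it carries even though the two oxygen-bearing groups of compound 2 and compound 3 could not be told apart. Nothing available here explains why 4-methylphenyl, with its 0 hydrogen-bond donors and 0 hydrogen-bond acceptors, gives the lowest number of the four.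

The compounds shown leave open whether the lower number comes from the methyl group itself or from losing the methoxy and hydroxy groups, a question that plain phenyl on the same carbon could help to settle. On these data alone, it also remains open whether a longer chain, as in 4-ethylphenyl, or an amine, as in 4-aminophenyl, would keep, extend or lose the lower number of compound 4.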